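The compounds below may be only part of what the source reports. "The series", "measured", "known", "first", "only" and "open" are said of these compounds alone.

Measured so far in an assay on CHO-K1 cells for displacement of a labelled ligand from adenosine receptor A1 (Homo sapiens), read by scintillation counting, with a stated time of 60 min; on this read-out higher numbers stand for weaker inhibition and lower numbers for stronger inhibition:
compound 1 `CCOc1cc(/C=N/Nc2nc(N)c3ncn([C@@H]4O[C@H](CO)[C@@H](O)[C@H]4O)c3n2)ccc1O` 6940 nM
compound 2 `COc1ccc(/C=N/Nc2nc(N)c3ncn([C@@H]4O[C@H](CO)[C@@H](O)[C@H]4O)c3n2)cn1` 2.6 nM

Among the compounds with values here, compound 2 gives the lower of the two numbers in this assay; the only measured step is a 2700-fold lower number from compound 1 to compound 2 (3.43 log units; beyond the scatter), a change of the aryl group on the carbon with a double bond to nitrogen, and it is large.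

Compound 3 `CSCC/C=N/Nc1nc(N)c2ncn([C@@H]3O[C@H](CO)[C@@H](O)[C@H]3O)c2n1` is the next compound in the series. Change: 2-(methylsulfanyl)ethyl in place of 6-methoxypyridin-3-yl on a carbon with a double bond to nitrogen. Within the data shown here, no measured step swaps the aromatic group for an open chain, so the step from compound 1 to compound 2 bears on it only in showing how strongly this assay responds to what sits on that carbon. With the ring removed altogether, compound 3 is expected to return to a weaker number than compound 2, with a 77-fold higher number from compound 2 to compound 3 (1.89 log units; beyond the scatter) as the expected step and wide uncertainty. Compound 3 is estimated at 200 nM, range 10 nM to 5000 nM.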

Compound 3, inhibition constant: > 10000 nM
Compound 3: no number, only a limit; the forecaster's own chance of this, stated with the estimate: 5%; at least 50-fold (1.69 log units) between middle value and limit.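

In this assay compound 3 gives only a limit of the assay, not a number: the limit of > 10000 nM in this assay, at which 1 of the 3 values shown sits. Even read as a floor, the change shows an at least 3800-fold higher number from compound 2 to compound 3 (3.58 log units; beyond the scatter), so the low number of compound 2 is not kept when 2-(methylsulfanyl)ethyl replaces 6-methoxypyridin-3-yl on a carbon with a double bond to nitrogen. The comparison with the other aromatic group gives only an at least 1.4-fold higher number from compound 1 to compound 3 (0.15 log units; that floor lies within the scatter), so no order can be set between those two compounds.

From the compounds shown here alone, it remains open whether the ring's absence or the sulfur of this chain goes with the weak result, and a plain butyl chain or a chain ending in an amine would help separate the two. Also open, going by these compounds, is which part of 6-methoxypyridin-3-yl goes with the low number of compound 2, which an unsubstituted phenyl would begin to test.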